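The source may hold more compounds than are shown below. What is called first, only, known or untested is meant among the compounds shown, and "the series" means these compounds.

Measured so far in a functional assay on the whole organism with Mus musculus as the target, with a stated time of 1 h; on this read-out higher numbers stand for an effect only at larger amounts of compound and lower numbers for an effect already at smaller amounts:
- compound 1 `Cc1ccc(-c2nc(N)c3cc(Cc4ccccc4)sc3n2)o1` gives 2.2 mg/kg here
- compound 2 `COc1ccccc1Cc1cc2c(N)nc(-c3ccc(C)o3)nc2s1` gives 0.8 mg/kg here

Of these two, compound 1 stands highest at 2.2 mg/kg on this scale. Among the measured compounds shown here, the only measured step is a 2.8-fold lower number from compound 1 to compound 2 (0.44 log units; beyond the scatter) and it belongs to methoxy in place of hydrogen on an aromatic carbon, which is not the carbon that changes next. Compound 3 `N#Cc1cccc(-c2nc(N)c3cc(Cc4ccccc4)sc3n2)c1` differs from compound 1 by 3-cyanophenyl in place of 5-methylfuran-2-yl on an aromatic carbon in a swap of 3-cyanophenyl in place of 5-methylfuran-2-yl on an aromatic carbon, between two ring nitrogen atoms. For the measured compounds named here, no measured pair shows a change at this carbon, so the step to compound 2 offers only a rough size and no direction. The estimated 1.4-fold higher number from compound 1 to compound 3 (0.13 log units; within the scatter) is therefore expected to be small, leaning slightly towards a higher number, with wide uncertainty. For compound 3 the expected value is 3 mg/kg with an estimated range from 0.8 mg/kg to 10 mg/kg around it.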

Compound 3, dose for half-maximal effect: < 1 mg/kg
Compound 3 gave a limit, no number; the forecaster's own chance of this, stated with the estimate: 5%; middle value at least 3.0-fold (0.47 log units) away from the limit.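

In this assay compound 3 gives < 1 mg/kg, which is a limit of the assay and not a number. Among the compounds shown here, the earlier pair changed only the benzyl side of the core, whereas this result is the first to show that the carbon between two ring nitrogen atoms responds to a change: 3-cyanophenyl in place of 5-methylfuran-2-yl gives an at least 2.2-fold lower number from compound 1 to compound 3 (0.34 log units; beyond the scatter). The five-membered aromatic ring with its oxygen is therefore not needed here for an effect at small amounts of compound, but the full size of the step stays unfixed: the limit of < 1 mg/kg in this assay, at which 1 of the 3 values shown sits.

As far as these compounds go, what remains open is whether the nitrile or the six-membered ring itself accounts for the step, which a plain phenyl group at this carbon would separate. Also open, from the compounds shown here alone, is how an amine or a carboxylic acid in place of the nitrile would read on this scale.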